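Sulfoxide to Sulfone on a Phenethyl Chain

A few compounds are considered here, and "the series" means these few. Any claim that something is new, unique, unknown or untested is made for them only; others in the source may bear on it.

Measured so far in a physicochemical assay for lipophilicity, read by spectrophotometry, using the shake flask method, measured as octanol-water partition; a lower number here means a more polar compound, a higher number a more lipophilic compound:
compound 1, `FC(F)OCCc1ccccc1`: 3.16
compound 2, `O=S(=O)(CCc1ccccc1)C(F)F`: 1.87
compound 3, `C[S+]([O-])CCc1ccccc1`: 0.63

Compound 3 stands lowest of the three, with compound 2 nearest and compound 1 furthest away, both beyond the scatter. The unmeasured compound 4, `CS(=O)(=O)CCc1ccccc1`, differs from compound 3 by a group of 4 heavy atoms (1 carbon, 2 oxygen, 1 sulfur; no ring) in place of a group of 3 heavy atoms (1 carbon, 1 oxygen, 1 sulfur; no ring), on a saturated chain carbon, two bonds along the chain from an aromatic carbon. Within the data shown here, no measured step exchanges a sulfoxide for a sulfone directly. Among the measured compounds shown here, the one step at hand, a number 2.53 log units lower from compound 1 to compound 3 (beyond the scatter), shows how far this chain can move in this assay, but it swaps an ether for the sulfoxide and does not settle the present change. Compound 2 also carries a sulfone on the same chain and gives 1.87 in this assay, with two fluorines that compound 4 lacks; the reading of compound 4 is therefore expected to fall between compound 3 and compound 2. The step of a number 0.47 log units higher from compound 3 to compound 4 (beyond the scatter) is expected to be modest and upward. Compound 4 is estimated at 1.1, within 0.6 to 1.7.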

Compound 4, partition coefficient: 0.82
Compound 4: the middle estimate sits 0.28 log units above what was measured; low and high end bracket the measured number.
By their numbers in this assay, from the lowest: compounds 3 and 4 (each within the scatter of the next); then compound 2; then compound 1.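

In this assay, methylsulfonyl in place of the sulfoxide group on a saturated chain carbon, two bonds along the chain from an aromatic carbon, gives a number 0.19 log units higher from compound 3 to compound 4 (within the scatter) and so does not separate the two groups at this position. The first step to isolate the group on the sulfonyl sulfur, methyl in place of difluoromethyl, gives a number 1.05 log units lower from compound 2 to compound 4 (beyond the scatter) and is large, so among these sulfones the change on the sulfur moves the number while the sulfoxide-to-sulfone exchange does not. Methylsulfonyl in place of difluoromethoxy gives a number 2.34 log units lower from compound 1 to compound 4 (beyond the scatter) and is likewise large, as the step to the sulfoxide was.

On these data alone, whether a longer chain would keep compound 3 and compound 4 within the scatter of each other, and where an amine or a carboxylic acid in the same place would read, stays open. Nothing at hand speaks to why these numbers fall as they do.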